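A Smaller Carboxy Ring on the Shared Core

The compounds below may be only part of what the source reports. "The series", "measured", "known", "first", "only" and "open" are said of these compounds alone.

In a functional assay on MC-38 cells (Mus musculus) for antiproliferative activity, read by CCK-8 assay, with a stated time of 48 h (on this read-out lower numbers stand for stronger inhibition and higher numbers for weaker inhibition), compound 1 `COc1ccc(/C=C\c2cc(OC)c(OC)c(OC)c2)cc1OCc1ccc(CNC(C)(C)C(=O)O)cc1` reads > 10000 nM, which is a limit of the assay and not a number. Going by the values given here, compound 2 `COc1ccc(/C=C\c2cc(OC)c(OC)c(OC)c2)cc1OCc1ccc(CN2CCCCC2C(=O)O)cc1` gives 5400 nM, the only exact value so far. Compound 3 `COc1ccc(/C=C\c2cc(OC)c(OC)c(OC)c2)cc1OCc1ccc(CN2CC[C@H](C(=O)O)C2)cc1` differs from it by one change on a saturated chain carbon bound to an aromatic carbon: 3-carboxypyrrolidin-1-yl in place of 2-carboxypiperidin-1-yl on a saturated chain carbon bound to an aromatic carbon. Among the compounds with values here, only one measured step involves this position, an at least 1.8-fold lower number from compound 1 to compound 2 (0.26 log units; that floor lies within the scatter). That step offers no basis for expecting a real shift, so the expected step is a 1.1-fold higher number from compound 2 to compound 3 (0.05 log units; within the scatter), with no change expected beyond the scatter. For compound 3 the estimated value is 6000 nM, with an expected range of 2000 nM to 15000 nM.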

Compound 3, half-maximal inhibitory concentration: > 10000 nM
Compound 3 gave a limit, no number; the forecaster's own chance of this, stated with the estimate: 30%; at least 1.6-fold (0.22 log units) between middle value and limit.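

Compound 3 gives only a limit of the assay, not a number, in this assay. Replacing 2-carboxypiperidin-1-yl with 3-carboxypyrrolidin-1-yl therefore gives an at least 1.8-fold higher number from compound 2 to compound 3 (0.26 log units; that floor lies within the scatter). The smaller carboxy ring thus gives no measurable value, leaving compound 2 with the only exact number, and the true size of the step stays hidden at the assay's ceiling: the limit of > 10000 nM in this assay, at which 2 of the 3 values shown sit.

The step linking compound 1 and compound 3 cannot be read. This change alters both ring size and carboxy placement, so 2-carboxypyrrolidin-1-yl could separate those two differences.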